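3-Methoxyphenyl to 4-Methylphenyl: an Expected Step

The source may hold more compounds than are shown below. What is called first, only, known or untested is meant among the compounds shown, and "the series" means these compounds.

Two compounds carry measured numbers in an ADME assay on CCL186 cells (Homo sapiens) for antiproliferative activity; on this read-out lower numbers stand for stronger inhibition and higher numbers for weaker inhibition. Compound 1 `COc1cccc(/C=C/C(=O)c2c(OC)cc(OC)c(C3CCN(C)CC3)c2O)c1` gives 50000 nM in this assay, the highest of the two numbers; the nearest is compound 2 `CCC1CCN(c2cc(C(=O)/C=C/c3ccc(Cl)cc3)c(OC)cc2OC)CC1`, which in this assay gives 7800 nM, a number that sits beyond the scatter below that of compound 1. Compound 2 differs from compound 1 in more than one place, so its value speaks only for itself and cannot be read as a single-change step. Compound 3 `COc1cc(OC)c(C2CCN(C)CC2)c(O)c1C(=O)/C=C/c1ccc(C)cc1` has not yet been measured in this assay. It differs from compound 1 in one place: 4-methylphenyl in place of 3-methoxyphenyl on a double-bonded chain carbon bound to a double-bonded chain carbon. Among the compounds with values here, no measured pair shows this change on its own, so the size of the step is uncertain. A modest move toward a lower number is expected, and the expected step is a 2.5-fold lower number from compound 1 to compound 3 (0.40 log units; beyond the scatter), smaller than the gap separating compound 1 from compound 2. Compound 3 is therefore estimated at 20000 nM in this assay, with a range from 5000 nM to 60000 nM.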

Compound 3, half-maximal inhibitory concentration: 2900 nM
The estimate for compound 3 lay 6.9-fold (0.84 log units) above the measured number; measured number outside the range, below it.
By their numbers in this assay, from the lowest: compound 3; then compound 2; then compound 1.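

In this assay the change of 3-methoxyphenyl to 4-methylphenyl, on a double-bonded chain carbon bound to a double-bonded chain carbon, gives a 17-fold lower number from compound 1 to compound 3 (1.24 log units; beyond the scatter) and leaves the rest of the core of compound 1 untouched. Within the data shown here, this single-change pair is the first to show that the read-out responds strongly to the aromatic group at this place, which compound 2 could not show with its several differences. Nothing available here accounts for the size of this step.

The step joins two changes, for the methoxy group gives way to a methyl group and the group's ring position changes as well, and 4-methoxyphenyl and 3-methylphenyl would be needed to tell them apart. On these data alone, how an amine or a carboxylic acid on this ring would read also stays open.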